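A few compounds are considered here, and "the series" means these few. Any claim that something is new, unique, unknown or untested is made for them only; others in the source may bear on it.

Compound 3 `CCOC(=O)N1CCN(CCCOc2ccc(C(=O)C3CC3)cc2)CC1` gives 79400 nM in an assay on isolated protein for binding affinity to histamine H2 receptor (Homo sapiens) (on this read-out higher numbers stand for weaker inhibition and lower numbers for stronger inhibition), the highest of the three numbers in hand. Among the compounds with values here, compound 1 `CCCCCC(=O)c1ccc(OCCCN2CCN(C(=O)OC)CC2)cc1` gives 12000 nM in this assay, and compound 2 `CCCCCC(=O)c1ccc(OCCCN2CCN(CCCC)CC2)cc1` gives 7590 nM; the only single-point step between them, a 1.6-fold lower number from compound 1 to compound 2 (0.20 log units; within the scatter), concerns butyl in place of methoxycarbonyl on an amine nitrogen in a ring. Compound 4 `CCOC(=O)N1CCN(CCCOc2ccc(C(=O)c3cccc(F)c3F)cc2)CC1` differs from compound 3 by 2,3-difluorophenyl in place of cyclopropyl on a carbonyl carbon. Within the data shown here, no measured step touches this carbonyl position. Among the measured compounds shown here, the only hint is that compound 1 with 12000 nM and compound 2 with 7590 nM carry a different group there and sit lower than compound 3, though each also differs elsewhere. A modest lowering is expected, a 3.2-fold lower number from compound 3 to compound 4 (0.50 log units; beyond the scatter). Compound 4 is estimated at 25000 nM in this assay, between 6000 nM and 100000 nM.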

Compound 4, inhibition constant: 17400 nM
Beside the measured number, compound 4's estimate is 1.4-fold (0.16 log units) above it; low and high end bracket the measured number.
By their numbers in this assay, from the lowest: compounds 2, 1 and 4 (each within the scatter of the next, the first and the last beyond it); then compound 3.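

Within the data shown here, the first measured step at this carbonyl position, 2,3-difluorophenyl in place of cyclopropyl, gives a 4.6-fold lower number from compound 3 to compound 4 (0.66 log units; beyond the scatter) in this assay, a change larger than the usual scatter. The number therefore depends on the group held by this carbonyl carbon, at least for this pair with the ethoxycarbonyl piperazine-bearing core they share. Nothing at hand explains the shift.

Still open, from the compounds shown here alone, is whether the ring or its two fluorines account for the step. A plain phenyl or a cyclohexyl on the carbonyl carbon would help separate these two possibilities.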